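Fluoro for hydrogen on the aryl amide series: working notes

A few compounds are considered here, and "the series" means these few. Any claim that something is new, unique, unknown or untested is made for them only; others in the source may bear on it.

Measured so far:
Compound 1, `Cn1ccc2c(Oc3ccc(NC(=O)c4cc5cccnc5n(-c5ccc(Br)cc5)c4=O)cc3)ncnc21`, in a functional assay on MCF7 cells (Homo sapiens) for cytotoxicity, read by MTT assay, with a stated time of 72 h (on this read-out higher numbers stand for weaker inhibition and lower numbers for stronger inhibition), gives 79400 nM.
Compound 2, `Cn1ccc2c(Oc3ccc(NC(=O)c4cc5cccnc5n(-c5ccc(Br)cc5)c4=O)cc3F)ncnc21`, in this assay gives 59400 nM.
Compound 3, `O=C(Nc1ccc(Oc2ncnc3[nH]ccc23)c(F)c1)c1cc2cccnc2n(-c2ccccc2)c1=O`, in this assay gives 45000 nM.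

Compound 2 differs from compound 1 by fluoro in place of hydrogen on an aromatic carbon, and that step reads a 1.3-fold lower number from compound 1 to compound 2 (0.13 log units; within the scatter). Compound 4, `O=C(Nc1ccc(Oc2ncnc3[nH]ccc23)c(F)c1)c1cc2cccnc2n(-c2ccc(F)cc2)c1=O`, differs from compound 3 by fluoro in place of hydrogen on an aromatic carbon. The difference between the core of compound 3 and the core of compound 1 is not broken down here. The two changes are of the same kind, though not the same: in one the fluoro enters ortho to a large group and meta to a large group, in the other para to a large group. Resting on the step from compound 1 to compound 2, the step from compound 3 to compound 4 in this assay is expected to be a 1.2-fold lower number from compound 3 to compound 4 (0.07 log units; within the scatter). Compound 4 is therefore estimated at 38000 nM, between 20000 nM and 72000 nM.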

Compound 4, half-maximal inhibitory concentration: 9230 nM
Compound 4: the middle estimate sits 4.1-fold (0.61 log units) above what was measured; measured number below the stated range.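

In this assay, the change from phenyl to 4-fluorophenyl gives a 4.9-fold lower number from compound 3 to compound 4 (0.69 log units; beyond the scatter). The size of the step from fluoro in place of hydrogen did not carry over from one core to the other: the same change on two cores in this assay, a 1.3-fold lower number (0.13 log units; within the scatter) from compound 1 to compound 2 and a 4.9-fold lower number (0.69 log units; beyond the scatter) from compound 3 to compound 4, 3.6-fold (0.56 log units) apart, beyond the scatter of two such steps. The fluoro of compound 4 enters para to a large group and that of compound 2 enters elsewhere, so these two steps do not separate the role of the core from that of the position, and they set no rule for the series.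

Still open, from the compounds shown here alone, is whether chloro, methoxy or an amine at the place of that fluoro on the core of compound 4 gives a step of similar size.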